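The source may hold more compounds than are shown below. What is called first, only, known or untested is meant among the compounds shown, and "the series" means these compounds.

Of the compounds shown here, three built on one shared core have been measured in an ADME assay on microsomes from liver (Homo sapiens) for metabolic stability, read by LC-MS, using NADPH, with a stated time of 30 min, tested at 1 uM; on this read-out higher numbers stand for a more stable compound and lower numbers for a less stable compound. Compound 1 `C=CC(=O)Nc1cc(Nc2ncc(Cl)c(Nc3ccccc3S(=O)(=O)C(C)C)n2)c(OC)cc1N(C)CCN(C)C` gives 16% in this assay. Compound 2 `C=CC(=O)Nc1cc(Nc2ncc(F)c(Nc3ccccc3S(=O)(=O)C(C)C)n2)c(OC)cc1N(C)CCN(C)C`, which carries a fluoro in place of the chloro on an aromatic carbon, gives 26%, and compound 3 `C=CC(=O)Nc1cc(Nc2nccc(Nc3ccccc3S(=O)(=O)C(C)C)n2)c(OC)cc1N(C)CCN(C)C`, which carries a hydrogen in place of that chloro, gives 5%. Among these three numbers compound 1 stands second highest: the step of a number 10 percentage points higher from compound 1 to compound 2 (within the scatter) lies within the scatter, whereas a number 11 percentage points lower from compound 1 to compound 3 (beyond the scatter) and a number 21 percentage points lower from compound 2 to compound 3 (beyond the scatter) both lie beyond it.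

Compound 4 `C=CC(=O)Nc1cc(Nc2ncc(Cl)c(Nc3ccccc3S(=O)(=O)N(C)C)n2)c(OC)cc1N(C)CCN(C)C` keeps the chloro of compound 1 and alters a different part of the molecule: dimethylamino in place of isopropyl on a sulfonyl sulfur. Among the measured compounds shown here, none of the measured steps concerns this place; every one of them exchanges the group on the aromatic carbon that carries chloro in compound 1, while the group on the sulfonyl sulfur is the same in compounds 1, 2 and 3. The measured steps therefore give no guide to the size or direction of this new change, and no step beyond the scatter is expected. Compound 4 is expected to give about 18% in this assay, with a range from 8% to 35%. The step expected for compound 4 is a number 2 percentage points higher from compound 1 to compound 4 (within the scatter).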

Compound 4, percent of the compound remaining: 11%
The estimate for compound 4 lay 7 percentage points above the measured number, and the stated range covers the measured number.
By their numbers in this assay, from the lowest: compounds 3, 4, 1 and 2 (each within the scatter of the next, the first and the last beyond it).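

Among the compounds shown here, this is the first view of the group on the sulfonyl sulfur, and in this assay dimethylamino in place of isopropyl gives a number 5 percentage points lower from compound 1 to compound 4 (within the scatter) and so cannot be told apart from isopropyl on this read-out, with the chloro kept. The exchange keeps the count at 3 heavy atoms and replaces one carbon with a nitrogen, and this swap does not produce a step beyond the scatter, while two of the steps at the aromatic carbon do. No measurement shown here bears on what lies behind this result.

The compounds shown leave open whether a different group on the sulfonyl sulfur, such as a cyclic amine like morpholine or a longer chain like n-butyl, would shift the number beyond the scatter. They also leave open whether dimethylamino on the sulfonyl sulfur would give a similar result when fluoro or hydrogen sits on the aromatic carbon that carries chloro in compound 1.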